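From a cyclopentylamino to a 4-ethylphenylamino analogue

This account rests on a few compounds, and the source may have more. Where it says the series, first, only, none or still open, it means among the compounds named here.

Of the compounds shown here, two built on the same core have been tested in a functional assay on MGC-803 cells (Homo sapiens) for inhibition, read by sulforhodamine B assay; a lower number here means a stronger inhibitor, a higher number a weaker inhibitor. Compound 1 `Cc1ccc(NC2=CC(=O)c3nc4n(c3C2=O)[C@H]2OC[C@@H](O)[C@H]2OC4)cc1` carries a 4-methylphenyl group on the amine nitrogen and gives 1420 nM. Compound 2 `O=C1C(NC2CCCC2)=CC(=O)c2c1nc1n2[C@H]2OC[C@@H](O)[C@H]2OC1` carries a cyclopentyl group on the same nitrogen, and for compound 2 the result is only a limit of the assay, > 16000 nM, so its true value is not known as a number; it sits at the limit of > 16000 nM in this assay, at which 1 of the 2 values shown sits.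

Compound 3 `CCc1ccc(NC2=CC(=O)c3c(nc4n3[C@H]3OC[C@@H](O)[C@H]3OC4)C2=O)cc1` has not yet been measured. It differs from compound 2 in one place: 4-ethylphenyl in place of cyclopentyl on an amine nitrogen. Since compound 3 resembles compound 1 more closely than compound 2 does, the step from compound 2 to compound 3 is expected to be a large gain in inhibition, an at least 10-fold lower number from compound 2 to compound 3 (1.02 log units; beyond the scatter), well beyond the usual scatter, because compound 1 gives 1420 nM in this assay. Compound 3 is therefore estimated at 1500 nM, with a likely range from 500 nM to 5000 nM.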

Compound 3, half-maximal inhibitory concentration: 1110 nM
Compound 3: the middle estimate sits 1.4-fold (0.13 log units) above what was measured; measured number inside the range.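

In this assay, the change from cyclopentylamino to (4-ethylphenyl)amino on this amine nitrogen is an at least 14-fold lower number from compound 2 to compound 3 (1.15 log units; beyond the scatter), so a pair differing in one place now shows that the group on this nitrogen strongly affects the read-out. Compound 2 stands at a limit of the assay and not at a number, so the full size of this step stays unknown: the limit of > 16000 nM in this assay, at which 1 of the 3 values shown sits.

Compound 1, with 4-methylphenyl, gives 1420 nM and compound 3, with 4-ethylphenyl, gives 1110 nM, two values within the usual scatter of each other, so these two groups cannot be told apart here.

As far as these compounds go, how a cyclohexyl group on this nitrogen would read remains open, and with it whether the aromatic ring itself carries the gain. The effect of a 4-methoxyphenyl or 4-butylphenyl group is open as well.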